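From fluoro to trifluoromethyl on the shared core

A few compounds are considered here, and "the series" means these few. Any claim that something is new, unique, unknown or untested is made for them only; others in the source may bear on it.

Compound 1 `CC(=O)Nc1ccc2oc(-c3ccccc3)cc(=O)c2c1`: 184000 nM
Compound 2 `COc1cccc(-c2cc(=O)c3cc(NC(C)=O)ccc3o2)c1`: > 404000 nM (a limit of the assay)
Compound 3 `CC(=O)Nc1ccc2oc(-c3cccc(F)c3)cc(=O)c2c1`: 240000 nM

All three compounds were tested in an ADME assay on MT4 cells (Homo sapiens) for cytotoxicity, read by MTT assay, with a stated time of 4 days; on this read-out higher numbers stand for lower toxicity in this test and lower numbers for higher toxicity in this test. Compound 3 lies close to compound 1, with a 1.3-fold higher number from compound 1 to compound 3 (0.12 log units; within the scatter). Compound 2 reached only a limit, so it gives no exact number for comparison.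

Compound 4 `CC(=O)Nc1ccc2oc(-c3cccc(C(F)(F)F)c3)cc(=O)c2c1` differs from compound 3 at one place: trifluoromethyl in place of fluoro on an aromatic carbon, with trifluoromethyl in place of fluoro on an aromatic carbon. Among the compounds with values here, no measured step makes this exact change. The closest guide is the fluoro step, a 1.3-fold higher number from compound 1 to compound 3 (0.12 log units; within the scatter). The methoxy step is larger, with an at least 2.1-fold higher number from compound 1 to compound 2 (0.34 log units; beyond the scatter), but it rests on the limit. The remaining step, an at least 1.6-fold lower number from compound 2 to compound 3 (0.22 log units; that floor lies within the scatter), rests on that limit too. Neither of these two steps involves trifluoromethyl, so a change beyond the scatter is not expected in this assay. The estimated step is a 1.1-fold lower number from compound 3 to compound 4 (0.04 log units; within the scatter). For compound 4 the expected value is 220000 nM, with an expected range from 110000 nM to 360000 nM.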

Compound 4, half-maximal cytotoxic concentration: 10000 nM
Beside the measured number, compound 4's estimate is 22-fold (1.34 log units) above it, outside the stated range (below it).
By their numbers in this assay, from the lowest: compound 4; then compounds 1 and 3 (each within the scatter of the next). At a limit, above all of these: compound 2.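

In this assay, neither fluoro nor methoxy in place of hydrogen at this position had given a lower number, whereas trifluoromethyl gives an 18-fold lower number from compound 1 to compound 4 (1.26 log units; beyond the scatter) and also a 24-fold lower number from compound 3 to compound 4 (1.38 log units; beyond the scatter) on the shared core. Among the groups shown, the direction of the change therefore depends on the group that enters, and only trifluoromethyl moves the number down beyond the scatter. Against methoxy the step is an at least 40-fold lower number from compound 2 to compound 4 (1.60 log units; beyond the scatter) and is only a floor, as compound 2 stands at a limit: the limit of > 404000 nM in this assay, at which 1 of the 4 values shown sits.

The compounds shown leave open whether this lower number belongs to trifluoromethyl alone or would also come with a chlorine atom, a methyl or a nitrile at this place. They also leave open whether trifluoromethyl elsewhere on the same ring would give a similar number.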